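Ethyl for methyl on an inactive acetyl oxime

This account rests on a few compounds, and the source may have more. Where it says the series, first, only, none or still open, it means among the compounds named here.

Compound 1 `COc1cc(C(OC(C)=O)c2ccc3c(ccn3C)c2)cc(OC)c1OC`: 240 nM
Compound 2 `COc1cc(/C(=N/OC(C)=O)c2ccc3c(ccn3C)c2)cc(OC)c1OC`: > 10000 nM (a limit)
Compound 3 `COc1cc(/C(=N\OC(C)=O)c2ccc3c(ccn3C)c2)cc(OC)c1OC`: > 10000 nM (a limit)

All three compounds were tested in a functional assay on HL-60 cells (Homo sapiens) for cytotoxicity, read by XTT assay, with a stated time of 72 h; a higher number here means a weaker inhibitor, a lower number a stronger inhibitor. Compound 1 gives a real number, 240 nM. Compound 2 reads > 10000 nM, which is a limit of the assay and not a number. Compound 3 reads > 10000 nM, which is also a limit and not a number. The set is therefore dominated by the limit of > 10000 nM in this assay, at which 2 of the 3 values shown sit.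

Compound 4 `CCn1ccc2cc(/C(=N/OC(C)=O)c3cc(OC)c(OC)c(OC)c3)ccc21` departs from compound 3 in one place: methyl in place of hydrogen on a saturated chain carbon bound to an aromatic nitrogen. Cut one bond further out, the same difference reads methyl to ethyl.

Among the compounds with values here, the only measured step between close relatives is a step that the two limits leave unreadable from compound 2 to compound 3. Within the data shown here, that step concerns (the fact that compounds 2 and 3 differ only in the configuration as drawn), so it says nothing about methyl to ethyl, and no measured step gives a size to carry over. What remains is the starting point, and compound 3 sits at > 10000 nM, a limit. For so slight a change, no readable step beyond the scatter is expected in this assay, and another limit is the likeliest report. The expected step is a step that the limit leaves unreadable from compound 3 to compound 4. For compound 4 the estimated value is 15000 nM, with an expected range from 6000 nM to 40000 nM.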

Compound 4, half-maximal inhibitory concentration: > 1000 nM
Compound 4 gave a limit, no number; the forecaster's own chance of this, stated with the estimate: 85%; the middle value does not contradict the limit.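

In this assay compound 4 gives > 1000 nM, which is a limit and not a number. Compound 3 gives > 10000 nM, also a limit, so no step can be read between compound 3 and compound 4. The compounds shown leave open whether methyl to ethyl makes any difference to cytotoxicity on these acetyl oximes.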